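The source may report more compounds than this note shows. Statements on the series, on what has been measured and on what is new or still open speak of the compounds shown alone.

Series notes. Compound 1 `CCOc1ccc(C(=O)/C=C/c2c(/C=C/c3ccc(OC)cc3)cc(OC)cc2OC)cc1` gives 8 ug/mL in a functional assay on HepG2 cells (Homo sapiens) for antiproliferative activity, read by MTT assay, with a stated time of 48 h; on this read-out higher numbers stand for weaker inhibition and lower numbers for stronger inhibition; compound 2 `COc1ccc(/C=C/c2cc(OC)cc(OC)c2/C=C/C(=O)c2ccc(Br)cc2)cc1` gives 12.9 ug/mL and compound 3 `COc1ccc(/C=C/c2cc(OC)cc(OC)c2/C=C/C(=O)c2ccc(C)cc2)cc1` gives 4.8 ug/mL. Compound 1 thus stands second highest of the three numbers, with a 1.6-fold higher number from compound 1 to compound 2 (0.21 log units; within the scatter) and a 1.7-fold lower number from compound 1 to compound 3 (0.22 log units; within the scatter), both within the scatter, whereas a 2.7-fold lower number from compound 2 to compound 3 (0.43 log units; beyond the scatter) is modest but beyond it. Compound 4 `COc1ccc(/C=C/c2cc(OC)cc(OC)c2/C=C/C(=O)c2ccc(C)cc2C)cc1` differs from compound 1 by 2,4-dimethylphenyl in place of 4-ethoxyphenyl on a carbonyl carbon. The steps from compound 1 to compound 2 and to compound 3 bear on this change and were both small; compound 3, which also carries a methyl at that position, is the closer precedent. For compound 4 the expected step in this assay is therefore a 1.6-fold lower number from compound 1 to compound 4 (0.20 log units; within the scatter), nothing beyond the scatter, leaning to a slightly lower number. Compound 4 is estimated at 5 ug/mL, within 2 ug/mL to 12 ug/mL.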

Compound 4, half-maximal inhibitory concentration: 0.9 ug/mL
Compound 4: the middle estimate sits 5.6-fold (0.74 log units) above what was measured, and the stated range ends above it.
By their numbers in this assay, from the lowest: compound 4; then compounds 3, 1 and 2 (each within the scatter of the next, the first and the last beyond it).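

On the carbonyl carbon, 2,4-dimethylphenyl gives an 8.9-fold lower number from compound 1 to compound 4 (0.95 log units; beyond the scatter) in place of 4-ethoxyphenyl and a 14-fold lower number from compound 2 to compound 4 (1.16 log units; beyond the scatter) in place of 4-bromophenyl, so a change at this position can reach well beyond the scatter. One added methyl on the aromatic ring gives a 5.3-fold lower number from compound 3 to compound 4 (0.73 log units; beyond the scatter) even though the earlier swaps of ethoxy for methyl or bromo stayed within the scatter. Nothing here explains this shift.

On these data alone, whether an ethyl, a methoxy or an amine in place of the added methyl would keep the lower number stays open. Also open, as far as these compounds go, is whether the added methyl gives the same step without the methyl already present in compound 3.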